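Trifluoromethyl against trifluoromethoxy in a cytotoxicity series

This account rests on a few compounds, and the source may have more. Where it says the series, first, only, none or still open, it means among the compounds named here.

Compound 1 `Cc1ccc2nc(-c3cccc(C(F)(F)F)c3)[nH]c(=O)c2c1` and compound 2 `Cc1ccc2nc(-c3cccc(OC(F)(F)F)c3)[nH]c(=O)c2c1` share one core; compound 3 `Cc1ccc2c(=O)[nH]c(-c3cccc(OC(F)(F)F)c3)nc2c1` and compound 4 `Cc1ccc2c(=O)[nH]c(-c3cccc(C(F)(F)F)c3)nc2c1` share another, and the difference between the two cores is not broken down here. In a functional assay on HeLa cells (Homo sapiens) for cytotoxicity, read by MTT assay, with a stated time of 2 days (a lower number here means a stronger inhibitor, a higher number a weaker inhibitor), compound 1 gives > 50000 nM, which is a limit of the assay. In this assay compound 2 gives > 50000 nM, also a limit. In this assay compound 3 gives > 50000 nM, again a limit. The change trifluoromethyl in place of trifluoromethoxy on an aromatic carbon produced a step that the two limits leave unreadable from compound 2 to compound 1. The same change, (trifluoromethyl in place of trifluoromethoxy on an aromatic carbon), is made from compound 3 to compound 4, at the same place. Because (the limit of > 50000 nM in this assay, at which 3 of the 3 values shown sit), the step from compound 3 to compound 4 is expected to be a step that the limit leaves unreadable from compound 3 to compound 4 and likely unreadable. Compound 4 is expected to give 70000 nM, between 25000 nM and 300000 nM, most probably reported only as a limit.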

Compound 4, half-maximal inhibitory concentration: > 50000 nM
Compound 4: only a limit was reported; the forecaster's own chance of this, stated with the estimate: 90%; the middle value does not contradict the limit.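

Going by these compounds alone, compound 3 and compound 4 both sit at a limit, so no step between them can be read in this assay: the limit of > 50000 nM in this assay, at which 4 of the 4 values shown sit.

As far as these compounds go, whether trifluoromethyl and trifluoromethoxy differ at all in this assay, on either core, stays open.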